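The source may report more compounds than this note shows. Statements on the series, on what has been measured and on what is new or still open speak of the compounds shown alone.

Compound 1 `C=C1C(=O)O[C@H]2CC3=C[C@H](C/C(C)=C/[C@@H](OC(=O)CCCCBr)[C@H]12)OC3=O` is an ester of the shared core. In a functional assay on NCI-H460 cells (Homo sapiens) for cytotoxicity, read by MTT assay, with a stated time of 48 h (a lower number here means a stronger inhibitor, a higher number a weaker inhibitor), compound 1 gives only a limit of the assay, > 10000 nM. Compound 2 `C=C1C(=O)O[C@H]2CC3=C[C@H](C/C(C)=C/[C@@H](OC(=O)C4(NC(=O)OCc5ccccc5)CC4)[C@H]12)OC3=O` gives 3000 nM in this assay. So compound 1 stands at the weak end of what has been measured, at the limit of > 10000 nM in this assay, at which 1 of the 2 values shown sits. Compound 3 `C=C1C(=O)O[C@H]2CC3=C[C@H](C/C(C)=C/[C@@H](OC(=O)/C=C/c4ccncc4)[C@H]12)OC3=O` changes the ester group of compound 1: 2-(pyridin-4-yl)ethenyl in place of 4-bromobutyl on a carbonyl carbon. Because compound 2 reaches 3000 nM with another ester on the same core, a gain beyond the usual scatter is expected, an at least 2.5-fold lower number from compound 1 to compound 3 (0.39 log units; beyond the scatter). Compound 3 is expected to give 4000 nM in this assay, within a range from 1500 nM to 15000 nM.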

Compound 3, half-maximal inhibitory concentration: 2100 nM
Beside the measured number, compound 3's estimate is 1.9-fold (0.28 log units) above it, within the range that was stated.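

Going by these compounds alone, replacing 4-bromobutyl with 2-(pyridin-4-yl)ethenyl on this carbonyl carbon gives the first readable step at this position of the shared core: in this assay there is an at least 4.7-fold lower number from compound 1 to compound 3 (0.67 log units; beyond the scatter). The ester group here can therefore move the read-out beyond the usual scatter. On these data alone, the true size of the step stays unknown, since compound 1 gives only a limit: the limit of > 10000 nM in this assay, at which 1 of the 3 values shown sits.

The change swaps the chain, the double bond and the ring nitrogen together, and the compounds shown cannot tell which of these matters. Neither 2-phenylethenyl, which lacks the ring nitrogen, nor a plain butyl chain, which lacks the bromine, appears among them.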